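A few compounds are considered here, and "the series" means these few. Any claim that something is new, unique, unknown or untested is made for them only; others in the source may bear on it.

Within the data shown here, in a functional assay on NCI-H23 cells (Homo sapiens) for cytotoxicity, read by sulforhodamine B assay, with a stated time of 72 h (a higher number here means a weaker inhibitor of growth, a lower number a stronger inhibitor of growth), compound 2 `CCCCCCCCC(=O)N1c2ccccc2CCC1C(=O)Nc1ccccc1C(F)(F)F` gives 4220 nM, the second highest of the three numbers known. Its nearest neighbour is compound 3 `CCCCCCCCC(=O)N1c2ccccc2CCC1C(=O)Nc1cc(C(F)(F)F)cc(C(F)(F)F)c1`, which in this assay gives 3230 nM, a difference within the scatter; furthest away is compound 1 `O=C(Nc1ccccc1O)C1CCc2ccccc2N1C(=O)c1ccccc1Cl`, which in this assay gives 46900 nM, a gap beyond the scatter. Compound 4 `O=C(Nc1ccccc1C(F)(F)F)C1CCc2ccccc2N1C(=O)c1ccc(Cl)cc1` is not yet measured. It differs from compound 2 by 4-chlorophenyl in place of octyl on a carbonyl carbon. Among the measured compounds shown here, no pair of measured compounds shows this change alone, and compound 1, the only measured compound carrying an aryl group on that carbonyl, also differs elsewhere. Compound 4 is therefore expected to lose ground in this assay, with a step of a 3.6-fold higher number from compound 2 to compound 4 (0.55 log units; beyond the scatter) beyond the scatter. The estimate for compound 4 is 15000 nM, within 4000 nM to 60000 nM.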

Compound 4, concentration for 50% growth inhibition: 307 nM
Compound 4: middle estimate off by 49-fold (1.69 log units), on the high side, outside the stated range (below it).
By their numbers in this assay, from the lowest: compound 4; then compounds 3 and 2 (each within the scatter of the next); then compound 1.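

In this assay, the substituent on a carbonyl carbon emerges as a strong determinant of growth inhibition: 4-chlorophenyl in place of octyl gives a 14-fold lower number from compound 2 to compound 4 (1.14 log units; beyond the scatter). Among these compounds, this is the first change that can be read alone, and it shows that an aryl group here can bring a large gain rather than a loss. Nothing measured explains the step. The compounds shown leave open whether the gain needs the chlorine, as an unsubstituted phenyl or a butyl chain would test. They also leave open whether it carries over to other groups on the amide nitrogen.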